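A Methyl on the Chain Carbon of Compound 1

The source may hold more compounds than are shown below. What is called first, only, known or untested is meant among the compounds shown, and "the series" means these compounds.

Within the data shown here, compound 1 `CN(Cc1ccccc1)C(=O)c1ccc[nH]1` is one of two compounds measured in an assay on mitochondria for inhibition of Amine oxidase [flavin-containing] B (Bos taurus), read by fluorescence (on this read-out lower numbers stand for stronger inhibition and higher numbers for weaker inhibition), and in this assay compound 1 gives 150000 nM, the highest of the two numbers. The other measured compound, compound 2 `CN(CCCc1ccccc1)C(=O)c1ccc[nH]1`, whose structure stands beside it, gives in this assay 8900 nM, a number lower than that of compound 1 by more than the usual scatter. Compound 3 `CC(c1ccccc1)N(C)C(=O)c1ccc[nH]1` has not yet been measured. It differs from compound 1 by methyl in place of hydrogen on a saturated chain carbon bound to an amide-type nitrogen and an aromatic carbon. Among the measured compounds shown here, no measured pair here shows the effect of exactly this change, so the expectation rests on little. For compound 3 a small step downward, close to the edge of the scatter, is expected, namely a 2.1-fold lower number from compound 1 to compound 3 (0.33 log units; beyond the scatter). Compound 3 is therefore estimated at 70000 nM, with a range from 20000 nM to 300000 nM.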

Compound 3, inhibition constant: 4500 nM
Estimate against measurement, compound 3: 16-fold (1.19 log units) above; measured number outside the range, below it.
By their numbers in this assay, from the lowest: compounds 3 and 2 (each within the scatter of the next); then compound 1.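

In this assay, methyl in place of hydrogen on a saturated chain carbon bound to an amide-type nitrogen and an aromatic carbon gives a 33-fold lower number from compound 1 to compound 3 (1.52 log units; beyond the scatter) and so counts as a large step. This position is therefore not indifferent to what it carries: a single added carbon, with no ring, no hydrogen-bond donor or acceptor and no net charge, moves the number far beyond the scatter. No measurement here gives any reason for a step of this size.

As far as these compounds go, it remains open whether a longer chain, such as ethyl, on this same carbon would go further in the same direction or lose the gain. From the compounds shown here alone, what an amine or a hydroxyl group would do at this place also remains open.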